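An amino group on the chain of compound 2

A few compounds are considered here, and "the series" means these few. Any claim that something is new, unique, unknown or untested is made for them only; others in the source may bear on it.

Measured in an ADME assay on the whole organism (serum) with Homo sapiens as the target; a higher number here means that the compound lasts longer, a lower number that the compound disappears faster:
- compound 1 `Cc1cn(C2CC(N=[N+]=[N-])C(COC(=O)OCCCCCCO)O2)c(=O)[nH]c1=O`: 0.117 h
- compound 2 `CCCCOC(=O)OCC1OC(n2cc(C)c(=O)[nH]c2=O)CC1N=[N+]=[N-]`: 0.15 h

For the measured compounds named here, compound 2 cannot be ranked against the only other measured compound, as the two values lie within the scatter of each other. Compound 3 `Cc1cn(C2CC(N=[N+]=[N-])C(COC(=O)OCCCN)O2)c(=O)[nH]c1=O` differs from compound 2 as follows: amino in place of methyl on a saturated chain carbon, three bonds along the chain from an oxygen next to a carbonyl group. Going by the values given here, the sole measured step, a 1.3-fold higher number from compound 1 to compound 2 (0.11 log units; within the scatter), puts hydrogen in place of 2-hydroxyethyl, stays within the scatter and involves no amino group, so no step beyond the scatter is expected in this assay. The expected step is a 1.2-fold lower number from compound 2 to compound 3 (0.06 log units; within the scatter). For compound 3 the estimated value is 0.13 h, within an expected range of 0.05 h to 0.3 h.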

Compound 3, half-life: 0.133 h
Estimate against measurement, compound 3: 1.0-fold (0.01 log units) below; measured number inside the range.
By their numbers in this assay, from the lowest: compounds 1, 3 and 2 (each within the scatter of the next).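

In this assay, amino in place of methyl on a saturated chain carbon, three bonds along the chain from an oxygen next to a carbonyl group, stays within the scatter (a 1.1-fold lower number from compound 2 to compound 3 (0.05 log units; within the scatter)), and amino in place of 3-hydroxypropyl at that place does too (a 1.1-fold higher number from compound 1 to compound 3 (0.06 log units; within the scatter)). An amino group on this chain therefore sets compound 3 level with both a plain chain and a hydroxyl-bearing one. No available evidence accounts for this. The compounds shown leave open whether a carboxylic acid here, or a longer chain carrying the amine, would move the half-life beyond the scatter.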